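The compounds below may be only part of what the source reports. "The series", "measured", "known", "first", "only" and "open" are said of these compounds alone.

In an ADME assay on microsomes from liver (Mus musculus) for metabolic stability, read by LC-MS, using NADPH, tested at 1 uM (on this read-out lower numbers stand for a shorter-lived compound and higher numbers for a longer-lived compound), compound 1 (`CCC(=O)NC/C=C\CN(C)C[C@H]1O[C@@H](n2cnc3c(N)ncnc32)[C@H](O)[C@@H]1O`) gives > 1.5 h as a limit of the assay and not a number. Compound 2 (`CCCC(=O)NC/C=C\CN(C)C[C@H]1O[C@@H](n2cnc3c(N)ncnc32)[C@H](O)[C@@H]1O`) gives > 1.5 h as a limit too. Compound 3 (`Cc1nc2c(N)ncnc2n1[C@@H]1O[C@H](CN(C)C/C=C\CNC(=O)OC(C)(C)C)[C@H]2OC(C)(C)O[C@H]21`) gives < 0.0417 h as a limit and is the only one of the three at the short-lived end of the read-out. Compound 4 (`Cc1nc2c(N)ncnc2n1[C@@H]1O[C@H](CN(C/C=C\CNC(=O)OC(C)(C)C)C2CC2)[C@H]2OC(C)(C)O[C@H]21`) changes one place of compound 3: cyclopropyl in place of methyl on an amine nitrogen amounts to cyclopropyl in place of methyl on an amine nitrogen. Among the measured compounds shown here, the one measured step that the two limits leave unreadable from compound 1 to compound 2 sits on a saturated chain carbon and its size cannot be read from the two limits, so it gives no measure for this change. Any shift is therefore expected to stay within the scatter in this assay. For the measured compounds named here, the only anchor is compound 3 with its limit of < 0.0417 h for the estimate. The expected change is a step that the limit leaves unreadable from compound 3 to compound 4 as an estimate only. Compound 4 is expected at 0.03 h with an estimated range from 0.015 h to 0.06 h and will probably be reported only as a limit.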

Compound 4, half-life: < 0.0417 h
Compound 4 ended at the assay's limit (the forecaster's own chance of this, stated with the estimate: 80%); the middle value lies beyond the limit too.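

In this assay, compound 3 and compound 4 both stand at a limit of the assay and not at a number, so no new step can be read from them. The compounds shown leave open how far cyclopropyl in place of methyl on an amine nitrogen moves the half-life.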